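Cytotoxicity notes: aryl sulfonyl in place of butyl

The compounds below may be only part of what the source reports. "The series", "measured", "known", "first", "only" and "open" are said of these compounds alone.

Compound 1 `COc1ccc([C@H]2CC(=O)N(c3cccc(O)c3)C2)cc1OC1CCCC1` gives > 10000 nM in a functional assay on HEK293 cells (Homo sapiens) for cytotoxicity (a higher number here means that more compound is tolerated, a lower number that less compound is tolerated), a limit of the assay.
Compound 2 `COc1ccc([C@H]2CC(=O)N(c3ccccc3C)C2)cc1OC1CCCC1` gives > 10000 nM in this assay, a limit of the assay.
Compound 3 `CCCCNc1cccc(N2C[C@@H](c3ccc(OC)c(OC4CCCC4)c3)CC2=O)c1` gives > 10000 nM in this assay, a limit of the assay.

All three values sit at the limit of > 10000 nM in this assay, at which 3 of the 3 values shown sit. Compound 3 therefore stands only at a limit, and the two further values shown are limits as well, so no ordering among the three can be read.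

Compound 4 `COc1ccc([C@H]2CC(=O)N(c3cccc(NS(=O)(=O)c4cccc(F)c4)c3)C2)cc1OC1CCCC1` differs from compound 3 by (3-fluorophenyl)sulfonyl in place of butyl on a nitrogen on an aromatic ring. The measured steps that bear on this are a step that the two limits leave unreadable from compound 1 to compound 3, at the same nitrogen on the aromatic ring, and a step that the two limits leave unreadable from compound 1 to compound 2, at the amide-type nitrogen; neither size is readable due to the limit of > 10000 nM in this assay, at which 3 of the 3 values shown sit. No shift of the cytotoxicity limit has yet been seen in this series for any change at either position. The expectation for compound 4 is accordingly a step that the limit leaves unreadable from compound 3 to compound 4, that is, none beyond the scatter. Compound 4 is expected to give 15000 nM in this assay, within 5000 nM to 50000 nM, most probably reported again as a limit.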

Compound 4, half-maximal cytotoxic concentration: > 10000 nM
Compound 4 gave a limit, no number; the forecaster's own chance of this, stated with the estimate: 75%; the middle value is on the limit's open side.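

Compound 4 stands only at a limit, as do compound 1 and compound 3, so the steps from compound 1 and compound 3 to compound 4 cannot be read: the limit of > 10000 nM in this assay, at which 4 of the 4 values shown sit.

The compounds shown leave open which change to the shared core, if any, would give a number rather than a limit in this assay.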